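The compounds below may be only part of what the source reports. "The series", "measured", "known", "first", "only" and "open" are said of these compounds alone.

Compounds measured so far:

Compound 1, `Cc1ccccc1Nc1nc(SCc2ccc(C(F)(F)F)cc2)nc2ccccc12`, 36900 nM in a functional assay on PC-3 cells (Homo sapiens) for cytotoxicity, read by MTT assay, with a stated time of 72 h; a lower number here means a stronger inhibitor, a higher number a weaker inhibitor.
Compound 2, `FC(F)(F)c1ccc(CSc2nc(Nc3ccc(Cl)cc3)c3ccccc3n2)cc1`, 7110 nM.

Compound 2 gives the lowest of the two numbers in this assay, and the nearest measured neighbour is compound 1, which gives a number higher by the step of a 5.2-fold lower number from compound 1 to compound 2 (0.72 log units; beyond the scatter). For the measured compounds named here, that single step, in which a 4-chlorophenyl takes the place of a 2-methylphenyl on the nitrogen attached to the shared core, is the only measured comparison available.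

Compound 3, `O=[N+]([O-])c1ccc(Nc2nc(SCc3ccc(C(F)(F)F)cc3)nc3ccccc23)cc1`, has not yet been measured in this assay. It differs from compound 2 by nitro in place of chloro on an aromatic carbon, so the 4-chlorophenyl becomes a 4-nitrophenyl while the rest of the molecule is unchanged. Going by the values given here, no measured step concerns a nitro group, and the one step in hand, from a 2-methylphenyl to a 4-chlorophenyl, involves two changes at once, so it bears on this exchange only loosely. A step within or close to the usual scatter is therefore expected for compound 3, with the direction uncertain, and the estimate is 5000 nM, between 1500 nM and 15000 nM, corresponding to an expected step of a 1.4-fold lower number from compound 2 to compound 3 (0.15 log units; within the scatter).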

Compound 3, half-maximal inhibitory concentration: 7900 nM
Beside the measured number, compound 3's estimate is 1.6-fold (0.20 log units) below it; the measured number falls inside the stated range.
By their numbers in this assay, from the lowest: compounds 2 and 3 (each within the scatter of the next); then compound 1.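

In this assay the exchange of chloro for nitro on an aromatic carbon para to a large group, a 1.1-fold higher number from compound 2 to compound 3 (0.05 log units; within the scatter), leaves compounds 2 and 3 within the scatter of each other, so at this position a nitro group, with its hydrogen-bond acceptors, reads the same as a chloro group, which has none. Seen from the 2-methylphenyl of compound 1, the 4-nitrophenyl gives a 4.7-fold lower number from compound 1 to compound 3 (0.67 log units; beyond the scatter) and the 4-chlorophenyl gives a 5.2-fold lower number from compound 1 to compound 2 (0.72 log units; beyond the scatter), so the lower number of compound 2 is now shared by a second 4-substituted phenyl and no longer rests on chloro alone, although each of these steps changes both the group and its place on the ring. Nothing measured on these compounds accounts for this similarity or for the higher number of compound 1.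

The compounds shown leave open whether the higher number of compound 1 comes from the methyl group itself or from where it sits, which a 4-methylphenyl would separate, and whether an unsubstituted phenyl or a 4-aminophenyl would stand with compounds 2 and 3. They also leave open how far the number depends on the trifluoromethyl group, which all three compounds carry unchanged, and what a carboxylic acid in its place would give.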